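This account rests on a few compounds, and the source may have more. Where it says the series, first, only, none or still open, it means among the compounds named here.

Among the compounds with values here, compound 2 `CC(C)CN1C(=O)c2ccccc2[C@H](C(=O)Nc2ccc(F)c(C#N)c2)[C@H]1c1cccs1` gives 2000 nM in a physicochemical assay for solubility, at pH 7.4; on this read-out higher numbers stand for higher solubility and lower numbers for lower solubility; the only other compound measured, compound 1 `CC(C)CN1C(=O)c2ccccc2[C@H](C(=O)Nc2cccc(C#N)n2)[C@H]1c1cccs1`, gives 1000 nM, and the two lie within the scatter of each other, as the step of a 2.0-fold higher number from compound 1 to compound 2 (0.30 log units; within the scatter) shows. Compound 3 `CC(C)CN1C(=O)c2ccccc2[C@H](C(=O)Nc2ccc(F)c(C#N)c2)[C@H]1c1ccc(C#N)s1` differs from compound 2 by cyano in place of hydrogen on an aromatic carbon. Within the data shown here, no measured step touches the thiophene ring, so the one step available, which was within the scatter, is only a loose guide. The expected step is a 1.3-fold lower number from compound 2 to compound 3 (0.12 log units; within the scatter). Compound 3 is estimated at 1500 nM, within a range from 500 nM to 5000 nM.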

Compound 3, solubility: 57000 nM
Compound 3: middle estimate off by 38-fold (1.58 log units), on the low side, and the stated range ends below it.
By their numbers in this assay, from the lowest: compounds 1 and 2 (each within the scatter of the next); then compound 3.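

In this assay, the thiophene carbon next to the ring sulfur proves highly sensitive: adding cyano, only 2 heavy atoms, gives a 29-fold higher number from compound 2 to compound 3 (1.45 log units; beyond the scatter) and is beyond the scatter. The amide-side swap, by contrast, gave only a 2.0-fold higher number from compound 1 to compound 2 (0.30 log units; within the scatter) and stayed within the scatter. Nothing available explains the size of the new step. As far as these compounds go, whether an amine, a carboxylic acid or a methyl group on this carbon would act like cyano remains open. So does whether cyano would have the same effect alongside the 6-cyanopyridin-2-yl group of compound 1.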